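The source may hold more compounds than are shown below. What is called first, only, known or untested is meant among the compounds shown, and "the series" means these compounds.

Measured so far:
- compound 1 `CC1=CC[C@H](C(C)(C)NC(=S)N/N=C/c2ccccc2)CC1`: 67000 nM
- compound 2 `COc1cc(/C=N/NC(=S)NC(C)(C)[C@H]2CC=C(C)CC2)ccc1O`: 35400 nM

Both numbers come from a functional assay on 786-0 cells (Homo sapiens) for inhibition, read by sulforhodamine B assay, with a stated time of 48 h; a higher number here means a weaker inhibitor of growth, a lower number a stronger inhibitor of growth. Compound 1 has the higher of the two numbers in this assay, and its nearest neighbour, compound 2, is within the usual scatter of it; the two values therefore tell nothing about an order between them, only that both sit in the same weak range. For the measured compounds named here, no pair of measured compounds that differs in a single place is available, so no step has been quantified yet.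

Compound 3 `CC1=CC[C@H](C(C)(C)NC(=S)N/N=C/c2ccco2)CC1` is not yet measured. It differs from compound 1 in one place: furan-2-yl in place of phenyl on a carbon with a double bond to nitrogen. Going by the values given here, the change is the exchange of one aromatic ring for another on the carbon with a double bond to nitrogen, and the two measured compounds give no step that speaks to such an exchange. The expectation for this assay is a step of no clear direction and not beyond the scatter, that is a 1.0-fold higher number from compound 1 to compound 3 (0.02 log units; within the scatter). Compound 3 is accordingly expected to give about 70000 nM in this assay, with a range from 30000 nM to 160000 nM.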

Compound 3, concentration for total growth inhibition: 9800 nM
Estimate against measurement, compound 3: 7.1-fold (0.85 log units) above; the whole stated range lies above it.
By their numbers in this assay, from the lowest: compound 3; then compounds 2 and 1 (each within the scatter of the next).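

In this assay, for the compounds shown here, the aromatic ring on the carbon with a double bond to nitrogen proves not to be interchangeable: furan-2-yl in place of phenyl gives a 6.8-fold lower number from compound 1 to compound 3 (0.83 log units; beyond the scatter), the first quantified step and one beyond the scatter. Going by these compounds alone, the earlier pair offered no single-place step, so this is the first indication that the series responds to the identity of the ring at this position, with the shared core unchanged. The exchange alters several counted features at once, replacing a six-membered aromatic ring of carbon only with a five-membered aromatic ring with one hetero atom and bringing in one hydrogen-bond acceptor, and no measurement here bears on which of these accounts for the step.

The compounds shown leave open whether the ring oxygen itself matters or whether another five-membered ring would serve equally, a question that thiophen-2-yl, with sulfur in place of oxygen, or pyridin-2-yl, a six-membered ring carrying nitrogen, would address directly. Also open, on these data alone, is how far the step holds when the furan ring carries a substituent such as methyl or bromo, or when the shared core is changed elsewhere.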